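The source may report more compounds than this note shows. Statements on the series, on what has been measured and on what is new or still open speak of the compounds shown alone.

Working notes on the series.

Of the compounds shown here, three have numbers so far. Compound 1 `CS/C(=N\C(=O)c1sccc1Cl)NC(=O)c1sccc1Cl` gives 57400 nM in a functional assay on PC-3 cells (Homo sapiens) for cytotoxicity, read by MTT assay, with a stated time of 72 h; a lower number here means a stronger inhibitor of growth, a higher number a weaker inhibitor of growth. Compound 2 `O=C(/N=C(/NC(=O)c1cc(-c2ccccc2)nc2ccccc12)[Se]Cc1ccccc1)c1cc(-c2ccccc2)nc2ccccc12` gives 97100 nM in this assay, and compound 3 `C[Se]/C(=N\C(=O)c1cnc2ccccc2c1)NC(=O)c1cnc2ccccc2c1` gives 43600 nM in this assay. On these numbers compound 3 carries the lowest value of the three; its gap to compound 1 lies within the scatter, so no order between the two can be read, while its gap to compound 2 lies beyond the scatter.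

The next compound, compound 4 `O=C(/N=C(/NC(=O)c1cnc2ccccc2c1)[Se]Cc1ccccc1)c1cnc2ccccc2c1`, keeps the core of compound 3 and changes one place: phenyl in place of hydrogen on a saturated chain carbon bound to a selenium atom. Cut one bond further out, the change reads methyl to benzyl. Among the measured compounds shown here, no measured pair in this set carries that same change on a shared core, so the size of the step has no direct precedent. Compound 2, which also bears a benzyl on the selenium but on a different core, sits at the high end of the three numbers, which offers only a loose pointer. A modest move toward a higher number is expected, and the step from a 1.6-fold higher number from compound 3 to compound 4 (0.21 log units; within the scatter) is the estimated size, possibly no further than the scatter. Compound 4 is expected to give about 70000 nM in this assay, with a range from 30000 nM to 160000 nM.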

Compound 4, concentration for total growth inhibition: > 100000 nM
Compound 4 was reported as a limit (the forecaster's own chance of this, stated with the estimate: 10%); middle value at least 1.4-fold (0.15 log units) from the limit.
By their numbers in this assay, from the lowest: compounds 3, 1 and 2 (each within the scatter of the next, the first and the last beyond it). At a limit, above all of these: compound 4.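

Phenyl in place of hydrogen on a saturated chain carbon bound to a selenium atom now has its first reading on a shared core: in this assay the change gives an at least 2.2-fold higher number from compound 3 to compound 4 (0.36 log units; beyond the scatter). The value of compound 4, > 100000 nM, is a limit and not a number, so the step fixes a direction and a minimum size only: the limit of > 100000 nM in this assay, at which 1 of the 4 values shown sits. Until this pair the change from methyl to benzyl had no reading on any single core, and its direction at this place is now shown, for this one core only.

Still open, as far as these compounds go, is whether the higher number goes with the phenyl ring itself or with any added length on the selenium atom: an ethyl group or a longer saturated chain there, or a benzyl carrying an amine or a carboxylic acid on its ring, would tell these apart. Also open, from the compounds shown here alone, is whether methyl to benzyl gives a step of similar direction and size on the core of compound 1.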